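Trading the hydroxypropyl amine for a cyclobutyl amine

The source may hold more compounds than are shown below. What is called first, only, known or untested is meant among the compounds shown, and "the series" means these compounds.

Measured compounds:
compound 1, `OCCCNc1nc(-c2ccccc2)nc2c1nnn2Cc1ccccc1Cl`: 33000000 nM
compound 2, `OCCCNc1nc(-c2ccccc2)nc2c1nnn2Cc1ccccc1`: 21400000 nM
compound 3, `OCCCNc1nc(-c2ccccc2)nc2c1nnn2Cc1ccccc1F`: 3700000 nM

In an assay on isolated protein for binding affinity to adenosine receptor A1 (Bos taurus) (a lower number here means a stronger inhibitor, a higher number a weaker inhibitor), compound 2 stands second highest of the three numbers. Its nearest neighbour is compound 1, with a 1.5-fold lower number from compound 1 to compound 2 (0.19 log units; within the scatter); its furthest is compound 3, with a 5.8-fold lower number from compound 2 to compound 3 (0.76 log units; beyond the scatter), and the step of an 8.9-fold lower number from compound 1 to compound 3 (0.95 log units; beyond the scatter) points the same way.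

Compound 4, `c1ccc(Cn2nnc3c(NC4CCC4)nc(-c4ccccc4)nc32)cc1`, arises from compound 2 by the change (cyclobutyl in place of 3-hydroxypropyl on a nitrogen on an aromatic ring). All three measured steps concern the substituent on the aromatic carbon of the benzyl group; none of them touches the amine substituent, so none bears directly on this step. The change itself is of a different kind from anything measured here, which leaves the direction open. Compound 4 is therefore expected to land near compound 2, with a broad range, the expected step being a 2.1-fold lower number from compound 2 to compound 4 (0.33 log units; beyond the scatter). The estimate for compound 4 in this assay is 10000000 nM, spanning 1500000 nM to 60000000 nM.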

Compound 4, inhibition constant: 5000000 nM
The estimate for compound 4 lay 2.0-fold (0.30 log units) above the measured number, within the range that was stated.
By their numbers in this assay, from the lowest: compounds 3 and 4 (each within the scatter of the next); then compounds 2 and 1 (each within the scatter of the next).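

In this assay, among these compounds, the change at the amine gives a 4.3-fold lower number from compound 2 to compound 4 (0.63 log units; beyond the scatter) and so lies beyond the scatter, which shows that this position, left unchanged in the earlier compounds, also moves the number. Cyclobutyl has neither the hydrogen-bond donor nor the hydrogen-bond acceptor of 3-hydroxypropyl, yet the number falls rather than rises, so in this pair the 3-hydroxypropyl group is not needed to reach the lower value. No measured evidence bears on why the number falls.

On these data alone, it remains open whether the step follows from the ring or from the loss of the oxygen, a question that a plain butyl chain on the same nitrogen could help to separate. Also open, as far as these compounds go, is whether fluoro on the benzyl group and cyclobutyl on the amine would add up in a single compound.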